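This account rests on a few compounds, and the source may have more. Where it says the series, first, only, none or still open, it means among the compounds named here.

Of the compounds shown here, three have been measured in a toxicity assay on the whole organism (strain Icem-CET (SPF Caw)) for cytotoxicity, with Mus musculus as the target; on this read-out lower numbers stand for an effect already at smaller amounts and higher numbers for an effect only at larger amounts of compound.

Measured compounds:
compound 1, `C#CCNC(=O)/C(C)=C(\C)c1ccc(Cl)cc1`, gives 400 mg/kg
compound 2, `C#CCNC(=O)/C(C)=C(\C)c1ccc(C)cc1`, gives 200 mg/kg
compound 3, `C/C(C(=O)NC1CC1)=C(/C)c1ccc(Cl)cc1`; for compound 3 the read-out is only a limit, > 800 mg/kg

Within the pair sharing the propargyl amide, the step in this assay from compound 1 to compound 2 is a 2.0-fold lower number from compound 1 to compound 2 (0.30 log units; within the scatter). The change behind it is methyl in place of chloro on an aromatic carbon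

The two cores of the series differ as follows: cyclopropyl in place of propargyl on an amide-type nitrogen
The step for that change is an at least 2.0-fold higher number from compound 1 to compound 3 (0.30 log units; that floor lies within the scatter); it is a floor rather than a number, since the value of compound 3 is the limit of the assay, (the limit of > 800 mg/kg in this assay, at which 1 of the 3 values shown sits).

Compound 4, `C/C(C(=O)NC1CC1)=C(/C)c1ccc(C)cc1`, has not yet been measured in this assay. It differs from compound 3 by methyl in place of chloro on an aromatic carbon
The place is described in the same words for both pairs, so this is the same change as that from compound 1 to compound 2.

For compound 4 the step from compound 3 is expected to be a number no higher from compound 3 to compound 4 (the limit leaves the size open), resting on the step seen from compound 1 to compound 2, a 2.0-fold lower number from compound 1 to compound 2 (0.30 log units; within the scatter). Since the value of compound 3 is itself a limit, compound 4 may again sit at the limit or just under it; the estimate for compound 4 in this assay is 800 mg/kg, with a range from 400 mg/kg to 2000 mg/kg.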

Compound 4, dose for half-maximal effect: 300 mg/kg
Compound 4: the middle estimate sits 2.7-fold (0.43 log units) above what was measured, outside the stated range (below it).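

In this assay, methyl in place of chloro on an aromatic carbon gives, on the cyclopropyl amide, an at least 2.6-fold lower number from compound 3 to compound 4 (0.42 log units; beyond the scatter), and set beside the same change on the propargyl amide it reads: the same change on two cores in this assay, a 2.0-fold lower number (0.30 log units; within the scatter) from compound 1 to compound 2 and an at least 2.6-fold lower number (0.42 log units; beyond the scatter) from compound 3 to compound 4; the limit leaves it open whether they differ

Compound 3 stands only at a limit, > 800 mg/kg, so the step on this core has a floor and no size, and the result neither establishes nor excludes that the change carries across the two cores at equal size.

The other change, cyclopropyl in place of propargyl on an amide-type nitrogen, now also has a step with a measured value at each end, a 1.5-fold higher number from compound 2 to compound 4 (0.18 log units; within the scatter), and compared across the chloro and methyl compounds it reads: the same change on two cores in this assay, an at least 2.0-fold higher number (0.30 log units; that floor lies within the scatter) from compound 1 to compound 3 and a 1.5-fold higher number (0.18 log units; within the scatter) from compound 2 to compound 4; the limit leaves it open whether they differ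

On these data alone, the four compounds hold only chloro and methyl on the aromatic carbon, so whether the step looks the same with an amine or a carboxylic acid at that place stays open. Propargyl and cyclopropyl are likewise the only groups on the amide-type nitrogen, so a longer chain there remains an open case, and each change rests on just two pairs, which supports no pattern beyond these compounds.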